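Four sulfonamide ring groups and one untested thiazole

A few compounds are considered here, and "the series" means these few. Any claim that something is new, unique, unknown or untested is made for them only; others in the source may bear on it.

Values in an ADME assay on liver (Rattus norvegicus) for metabolic stability, read by LC-MS, using microsomes and NADPH, with a stated time of 40 min, tested at 1 uM (a higher number here means faster removal of the compound, a lower number slower removal), for the measured compounds
compound 1 `COc1cc(C(F)(F)F)ccc1-c1cccc2cc(S(=O)(=O)Nc3ncns3)ccc12` gives 18 mL.min-1.g-1
compound 2 `COc1cc(C(F)(F)F)ccc1-c1cccc2cc(S(=O)(=O)Nc3ccncn3)ccc12` gives < 14 mL.min-1.g-1 as a limit of the assay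
compound 3 `COc1cc(C(F)(F)F)ccc1-c1cccc2cc(S(=O)(=O)Nc3cncs3)ccc12` gives 37 mL.min-1.g-1

Of the two exact numbers, the lower belongs to compound 1 at 18 mL.min-1.g-1 and the higher to compound 3. The value of compound 2 is a limit and not a number.

Compound 4 `COc1cc(C(F)(F)F)ccc1-c1cccc2cc(S(=O)(=O)Nc3cscn3)ccc12` has not yet been measured, and its difference from compound 1 reads 1,3-thiazol-4-yl in place of 1,2,4-thiadiazol-5-yl on a sulfonamide nitrogen in full, that is, 1,3-thiazol-4-yl in place of 1,2,4-thiadiazol-5-yl on a sulfonamide nitrogen.

Two measured steps leave the same group. The closest guide is the change to 1,3-thiazol-5-yl, which gives a 2.1-fold higher number from compound 1 to compound 3 (0.31 log units; beyond the scatter) as its result. The change to pyrimidin-4-yl gives an at least 1.2-fold lower number from compound 1 to compound 2 (0.10 log units; that floor lies within the scatter) and sets no firm direction. The remaining step, an at least 2.6-fold higher number from compound 2 to compound 3 (0.42 log units; beyond the scatter) in size, shows that these groups can separate clearly.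

A move toward a higher number is therefore expected, though it may stay inside the scatter. The expected step is a 1.7-fold higher number from compound 1 to compound 4 (0.22 log units; within the scatter) by this reasoning. In this assay for compound 4 the estimated value is 30 mL.min-1.g-1 with an expected range from 15 mL.min-1.g-1 to 60 mL.min-1.g-1 around it.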

Compound 4, intrinsic clearance in microsomes in the Rattus norvegicus assay: < 14 mL.min-1.g-1
Compound 4: a limit, no number; the forecaster's own chance of this, stated with the estimate: 10%; middle value at least 2.1-fold (0.33 log units) from the limit.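

Exchanging 1,3-thiazol-5-yl for 1,3-thiazol-4-yl on the sulfonamide nitrogen gives in the Rattus norvegicus assay an at least 2.6-fold lower number from compound 3 to compound 4 (0.42 log units; beyond the scatter), so the two thiazole groups do not behave as one group at this position. The result for compound 4 is a limit of the assay and not a number, which leaves an at least 1.2-fold lower number from compound 1 to compound 4 (0.10 log units; that floor lies within the scatter) without a firm order, and the step between compound 2 and compound 4 cannot be read. In a physicochemical assay for acid dissociation, read by capillary electrophoresis, at pH 1.7, compound 1 gives 3.7 and compound 4 gives 7.2. The change away from 1,2,4-thiadiazol-5-yl also has a large measured effect on how readily the proton is given up: the measured acid dissociation constant of compound 1, 3.7, and of compound 4, 7.2, a number 3.50 log units higher (beyond the scatter)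

The compounds shown leave open whether that shift in acid dissociation is tied to the clearance, and how far the true clearance of compound 4 lies under its limit. They also leave open whether a 1,3-oxazol-4-yl group, with oxygen in place of the ring sulfur, or a pyridin-2-yl group on the same sulfonamide nitrogen would follow 1,3-thiazol-4-yl or 1,3-thiazol-5-yl in the Rattus norvegicus assay.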